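Replacing a chloromethylphenyl ring with an aminophenyl ring

A few compounds are considered here, and "the series" means these few. Any claim that something is new, unique, unknown or untested is made for them only; others in the source may bear on it.

Of the compounds shown here, three have been measured in a functional assay (trachea) for antagonist activity, with Cavia porcellus as the target; a lower number here means a less potent compound, a higher number a more potent compound, by a factor of ten per unit of this negative logarithm. Compound 1 `COc1cc(C(=O)NS(=O)(=O)c2cccs2)ccc1Cn1ccc2ccc(NC(=O)CC3CCCC3)cc21` gives 9.6 in this assay. Compound 2 `COc1cc(C(=O)NS(=O)(=O)c2c(C)cccc2Cl)ccc1Cn1ccc2ccc(NC(=O)CC3CCCC3)cc21` gives 8.8, and compound 3 `CCCCOC(=O)Nc1ccc2ccn(Cc3ccc(-c4nn[nH]n4)cc3OC)c2c1` gives 7.2. Compound 2 therefore stands second of the three numbers: compound 1 lies above it beyond the scatter, and compound 3, which differs from it in several places at once, lies furthest below it, also beyond the scatter. Going by the values given here, the only measured step between compounds that differ in one place is a number 0.80 log units lower from compound 1 to compound 2 (beyond the scatter), the change of thiophen-2-yl to 2-chloro-6-methylphenyl on a sulfonyl sulfur.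

Compound 4 `COc1cc(C(=O)NS(=O)(=O)c2ccccc2N)ccc1Cn1ccc2ccc(NC(=O)CC3CCCC3)cc21` has not yet been measured. It differs from compound 2 at that same place: 2-aminophenyl in place of 2-chloro-6-methylphenyl on a sulfonyl sulfur. The step from compound 1 to compound 2 is the one that bears on this, and it showed that exchanging the ring on the sulfonyl sulfur shifts the number beyond the scatter. The entering 2-aminophenyl is, like thiophen-2-yl, a single ring carrying neither the chlorine nor the methyl, so the number is expected to recover part of that loss. For compound 4 the estimate is 9.2, with a range from 8.5 to 9.8. The expected step is a number 0.40 log units higher from compound 2 to compound 4 (beyond the scatter), a modest rise.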

Compound 4, negative logarithm of the antagonist equilibrium constant: 9.9
Compound 4: middle estimate off by 0.70 log units, on the low side; measured number outside the range, above it.
By their numbers in this assay, from the lowest: compound 3; then compound 2; then compounds 1 and 4 (each within the scatter of the next).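

In this assay, the ring on the sulfonyl sulfur can carry much more potency than the earlier step from thiophen-2-yl to 2-chloro-6-methylphenyl suggested. Exchanging 2-chloro-6-methylphenyl for 2-aminophenyl gives a number 1.10 log units higher from compound 2 to compound 4 (beyond the scatter) and is a large change, even though both groups contain one six-membered aromatic ring of carbon only. Comparison with the thiophen-2-yl compound gives a number 0.30 log units higher from compound 1 to compound 4 (within the scatter) and places 2-aminophenyl level with thiophen-2-yl, so having a six-membered ring at this place does not in itself cost potency, and what separates compound 2 from compound 4 lies in the groups on that ring.

The compounds shown change those groups together, with the chlorine and the methyl leaving as the amine enters, so a plain phenyl ring or a 2-chlorophenyl ring on the sulfonyl sulfur would be needed to tell whether the amine helps or the chlorine and methyl hurt. No measurement is available that explains why these rings differ in this way.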